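The source may report more compounds than this note shows. Statements on the series, on what has been measured and on what is new or still open speak of the compounds shown alone.

Measured compounds:
Compound 1 `C=C1C[C@]23C[C@@]1(O)CC[C@H]2c1ccc(OS(=O)(=O)c2ccc(C)cc2)c(C)c1[C@@H]3Cn1cc(-c2ccc(C)cc2)nn1`: in a functional assay on A549 cells (Homo sapiens) for cytotoxicity, read by MTT assay, with a stated time of 4 days (on this read-out higher numbers stand for weaker inhibition and lower numbers for stronger inhibition), compound 1 gives > 20000 nM, a limit of the assay rather than a number.
Compound 2 `C=C1C[C@]23C[C@@]1(O)CC[C@H]2c1ccc(OS(=O)(=O)c2ccc(C)cc2)c(C)c1[C@@H]3Cn1cc(-c2ccc(F)cc2)nn1`: in this assay compound 2 gives > 20000 nM, again a limit of the assay.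
Compound 3 `C=C1C(=O)[C@]23C[C@@]1(O)CC[C@H]2c1ccc(OS(=O)(=O)c2ccc(C)cc2)c(C)c1[C@@H]3Cn1cc(-c2ccc(F)cc2)nn1`: in this assay compound 3 gives 1950 nM.

Compound 2 and compound 1 share one core and differ only by methyl in place of fluoro on an aromatic carbon; the step that the two limits leave unreadable from compound 2 to compound 1 cannot be sized because both values sit at the limit of > 20000 nM in this assay, at which 2 of the 3 values shown sit. Compound 3 carries a different core, and how the two cores differ is not broken down here. Compound 4 `C=C1C(=O)[C@]23C[C@@]1(O)CC[C@H]2c1ccc(OS(=O)(=O)c2ccc(C)cc2)c(C)c1[C@@H]3Cn1cc(-c2ccc(C)cc2)nn1` stands to compound 3 as compound 1 stands to compound 2: the change is methyl in place of fluoro on an aromatic carbon, at the same place, so it is the same change. Because a step that the two limits leave unreadable from compound 2 to compound 1 could not be read, the matching step for compound 4 is expected to be small, a 1.1-fold higher number from compound 3 to compound 4 (0.05 log units; within the scatter). For compound 4 the estimate is 2200 nM, with a range from 900 nM to 6000 nM.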

Compound 4, half-maximal inhibitory concentration: 1830 nM
Compound 4: middle estimate off by 1.2-fold (0.08 log units), on the high side; measured number inside the range.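

In this assay, methyl in place of fluoro gives a 1.1-fold lower number from compound 3 to compound 4 (0.03 log units; within the scatter), so on the core of compound 3 the 4-fluorophenyl and 4-methylphenyl versions cannot be told apart. Going by these compounds alone, the same change on the other core cannot be read, because compound 1 and compound 2 both give a limit of the assay rather than a number: the limit of > 20000 nM in this assay, at which 2 of the 4 values shown sit. So the result fits a small effect on the core of compound 3, but it does not show that the change behaves alike on both cores, since only one readable step exists.

Fluoro and methyl are the only groups shown at this place on the aromatic ring. As far as these compounds go, whether an amine or a carboxylic acid there would shift the number beyond the scatter stays open.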